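This account rests on a few compounds, and the source may have more. Where it says the series, first, only, none or still open, it means among the compounds named here.

Measured compounds:
- compound 1, `COc1ccc(S(=O)(=O)Nc2cc(Br)cc(Cl)c2Cl)cc1N1CCNCC1`, gives 3.98 nM in an assay on isolated protein for binding affinity to 5-hydroxytryptamine receptor 6 (Homo sapiens); on this read-out higher numbers stand for weaker inhibition and lower numbers for stronger inhibition.
- compound 2, `COc1ccc(S(=O)(=O)Nc2cc(Br)cc(Br)c2F)cc1N1CCNCC1`, gives 2.51 nM in this assay.

Within the data shown here, compound 2 stands at the lowest of the two numbers so far; its nearest neighbour is compound 1, and the only measured step, a 1.6-fold lower number from compound 1 to compound 2 (0.20 log units; within the scatter), lies within the scatter, so the two cannot be placed in order. Compound 3, `COc1ccc(S(=O)(=O)Nc2cc(Br)cc(F)c2Cl)cc1N1CCNCC1`, has not yet been measured in this assay. It differs from compound 2 in one place: 5-bromo-2-chloro-3-fluorophenyl in place of 3,5-dibromo-2-fluorophenyl on a sulfonamide nitrogen. Among the measured compounds shown here, the single measured step that bears on this change is the exchange of one halogenated phenyl on the sulfonamide nitrogen for another, from compound 1 to compound 2, and that step was small. With compound 3 carrying a bromine, a chlorine and a fluorine on that ring, a pattern of substitution between those of compound 1 and compound 2, no step beyond the scatter is expected in this assay. Compound 3 is therefore expected to give 3.2 nM, within the range 1.5 nM to 7 nM. The step from compound 2 to compound 3 is expected to be a 1.3-fold higher number from compound 2 to compound 3 (0.11 log units; within the scatter).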

Compound 3, inhibition constant: 3.16 nM
Estimate against measurement, compound 3: 1.0-fold (0.01 log units) above; measured number inside the range.
By their numbers in this assay, from the lowest: compounds 2, 3 and 1 (each within the scatter of the next).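

In this assay the exchange of 3,5-dibromo-2-fluorophenyl for 5-bromo-2-chloro-3-fluorophenyl on a sulfonamide nitrogen gives a 1.3-fold higher number from compound 2 to compound 3 (0.10 log units; within the scatter) and so adds a third halogen pattern on this phenyl without a step beyond the scatter. Compound 3 also supplies an exchange of one halogen alone, fluoro in place of chloro on an aromatic carbon, and a 1.3-fold lower number from compound 1 to compound 3 (0.10 log units; within the scatter) is again within the scatter. Among these compounds, compound 1, compound 2 and compound 3 therefore cannot be placed in order, and this position has so far taken these three mixes of bromine, chlorine and fluorine with no step that can be told from the scatter.

As far as these compounds go, all three compounds carry only halogens on this phenyl, so it remains open how the number would respond to a nitrile, a trifluoromethyl group or an amine on the ring in place of one of them, or to a phenyl with no substituent at all. Nothing measured here accounts for the small size of these steps.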